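Aryl urea exchange on the shared core

A few compounds are considered here, and "the series" means these few. Any claim that something is new, unique, unknown or untested is made for them only; others in the source may bear on it.

Compound 1 `Cc1cccc(NC(=O)N[C@@H]2C[C@H](c3ccccc3C)C[C@H](c3ccccc3)N(CC(=O)NC(C)(C)C)C2=O)c1` gives 610 nM; 580 nM; 930 nM (3 entries) in an assay on isolated protein for inhibition of Cholecystokinin receptor type A (Cavia porcellus); on this read-out higher numbers stand for weaker inhibition and lower numbers for stronger inhibition; the repeats the several entries of compound 1 in this assay, 610 nM; 580 nM; 930 nM (3 entries) sit within the usual scatter. Compound 2 `Cc1ccccc1[C@@H]1C[C@H](c2ccccc2)N(CC(=O)NC(C)(C)C)C(=O)[C@H](NC(=O)Nc2cccc(C(F)(F)F)c2)C1` gives 2500 nM in this assay, the only number shown for it, with one further entry lacking a single number; it lies well above compound 1. Compound 3 `Cc1ccccc1[C@@H]1C[C@H](c2ccccc2)N(CC(=O)NC(C)(C)C)C(=O)[C@H](NC(=O)Nc2ccc(Cl)cc2)C1` carries 4-chlorophenyl in place of 3-(trifluoromethyl)phenyl on an amide-type nitrogen, that is, 4-chlorophenyl in place of 3-(trifluoromethyl)phenyl on an amide-type nitrogen. For the measured compounds named here, no measured step of this kind exists here. A modest loss, just beyond the scatter, is expected as a 1.8-fold higher number from compound 2 to compound 3 (0.26 log units; within the scatter). Compound 3 is estimated at 4500 nM, within 1200 nM to 16000 nM.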

Compound 3, half-maximal inhibitory concentration: > 10 nM
Compound 3: no number, only a limit; the forecaster's own chance of this, stated with the estimate: 15%; the middle value does not contradict the limit.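

For the compounds shown here, compound 3 gives > 10 nM in this assay as a limit and not a number, so no step from compound 2 to compound 3 can be read. Going by these compounds, whether 4-chlorophenyl in place of 3-(trifluoromethyl)phenyl on an amide-type nitrogen changes inhibition remains open.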